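Sgk1 series: ether substituent variation on the shared core

A few compounds are considered here, and "the series" means these few. Any claim that something is new, unique, unknown or untested is made for them only; others in the source may bear on it.

Measured compounds:
compound 1 `Cc1n[nH]c2nc(-c3ccc(NS(=O)(=O)c4cc(Cl)ccc4F)cc3)nc(OC3CCOCC3)c12` — 14 nM
compound 2 `Cc1n[nH]c2nc(-c3ccc(NS(=O)(=O)c4cc(Cl)ccc4F)cc3)nc(OCC3CNCCO3)c12` — 2 nM

For the measured compounds named here, in an assay for inhibition of serine/threonine-protein kinase Sgk1 (Homo sapiens), with stated times of 30 min and 60 min, in the presence of a further agent that is not named here (a higher number here means a weaker inhibitor, a lower number a stronger inhibitor), compound 2 gives the lower of the two numbers, and the only measured step, a 7.0-fold lower number from compound 1 to compound 2 (0.85 log units; beyond the scatter), separates it from compound 1. Compound 3 `Cc1n[nH]c2nc(-c3ccc(NS(=O)(=O)c4cc(Cl)ccc4F)cc3)nc(OC3CC(C)(C)NC(C)(C)C3)c12` carries 2,2,6,6-tetramethylpiperidin-4-yl in place of (morpholin-2-yl)methyl on an oxygen on an aromatic ring. Going by the values given here, no measured step covers this exact exchange. Among the compounds with values here, the single step that bears on it, a 7.0-fold lower number from compound 1 to compound 2 (0.85 log units; beyond the scatter), shows that moving from oxan-4-yl to a ring bearing a nitrogen donor lowered the number; compound 3 keeps such a donor in its ring, though the ring is again attached directly to the oxygen as in compound 1 and carries the four methyl groups. The expectation for compound 3 in this assay is therefore a number near that of compound 2, with a 2.0-fold higher number from compound 2 to compound 3 (0.30 log units; within the scatter) expected to stay within or only modestly beyond the scatter. The estimate for compound 3 is 4 nM, in the range 1 nM to 15 nM.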

Compound 3, half-maximal inhibitory concentration: 4 nM
Compound 3: the middle estimate sits on the measured number at the digits printed; measured number inside the range.
By their numbers in this assay, from the lowest: compounds 2 and 3 (each within the scatter of the next); then compound 1.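

At this position, on an oxygen on an aromatic ring, this assay does not separate 2,2,6,6-tetramethylpiperidin-4-yl from (morpholin-2-yl)methyl (a 2.0-fold higher number from compound 2 to compound 3 (0.30 log units; within the scatter)), so this exchange of rings shows no readable effect. Against oxan-4-yl, the new group gives a step beyond the scatter (a 3.5-fold lower number from compound 1 to compound 3 (0.54 log units; beyond the scatter)), which extends the lower number seen with compound 2 to a nitrogen-bearing ring attached directly to the oxygen, with no methylene link. No evidence is available on what underlies either step.

Whether the ring nitrogen or the four methyl groups account for the step from compound 1 remains open. A plain piperidin-4-yl, an open-chain amine or a carboxylic acid on the same oxygen would separate these contributions.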